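The source may hold more compounds than are shown below. What is called first, only, known or untested is meant among the compounds shown, and "the series" means these compounds.

Compound 2 `COc1ccc(-c2nn(-c3ccccc3)cc2C(=O)/C=C\Nc2ccc(C(F)(F)F)cc2)cc1` carries a trifluoromethyl group on an aromatic carbon of the shared core. In a functional assay on HT-29 cells (Homo sapiens) for antiproliferative activity, read by MTT assay, with a stated time of 48 h (a higher number here means a weaker inhibitor, a lower number a stronger inhibitor), compound 2 gives 9870 nM, the highest of the two numbers in hand; its nearest neighbour is compound 1 `COc1ccc(-c2nn(-c3ccccc3)cc2C(=O)/C=C\Nc2ccc(Cl)cc2)cc1`, which in this assay gives 4760 nM. For the measured compounds named here, the single measured step between them, a 2.1-fold higher number from compound 1 to compound 2 (0.32 log units; beyond the scatter), is the only change at that aromatic carbon for which a number exists. Compound 3 `COc1ccc(N/C=C\C(=O)c2cn(-c3ccccc3)nc2-c2ccc(OC)cc2)cc1` is the next member; relative to compound 2 it differs by methoxy in place of trifluoromethyl on an aromatic carbon. Going by the values given here, no measured step exchanges a trifluoromethyl for a methoxy, so only the chloro-to-trifluoromethyl step bears on the question, and it shows that a swap of this kind shifted this assay by a modest amount. The step from compound 2 is therefore expected to be small, estimated as a 1.6-fold lower number from compound 2 to compound 3 (0.22 log units; within the scatter). Compound 3 is expected to give 6000 nM in this assay, within a range from 2500 nM to 20000 nM.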

Compound 3, half-maximal inhibitory concentration: 8760 nM
The estimate for compound 3 lay 1.5-fold (0.16 log units) below the measured number, and the stated range covers the measured number.
By their numbers in this assay, from the lowest: compounds 1, 3 and 2 (each within the scatter of the next, the first and the last beyond it).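

In this assay, methoxy in place of trifluoromethyl on this aromatic carbon gives a 1.1-fold lower number from compound 2 to compound 3 (0.05 log units; within the scatter) and so does not separate the two compounds, although a group with no hydrogen-bond acceptor gives way to one with a hydrogen-bond acceptor. Methoxy in place of chloro gives a 1.8-fold higher number from compound 1 to compound 3 (0.26 log units; within the scatter), which places compound 3 within the scatter of both other compounds, and the only step beyond the scatter remains a 2.1-fold higher number from compound 1 to compound 2 (0.32 log units; beyond the scatter) in this series. No measurement is at hand that would account for these numbers.

On these data alone, whether an amine, a carboxylic acid or a longer chain at this aromatic carbon would shift the number beyond the scatter remains open. It is also open whether the three groups shown would stand in the same relation on other cell lines.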